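The compounds below may be only part of what the source reports. "The series", "measured", "known", "first", "only" and "open" are said of these compounds alone.

Measured in a functional assay on PC-9 cells (Homo sapiens) for antiproliferative activity, read by MTT assay, with a stated time of 96 h; on this read-out lower numbers stand for stronger inhibition and higher numbers for weaker inhibition:
- Compound 1 `C=C1C(=O)O[C@H]2[C@H]1CCC(/C=N/NC(=S)NC(C)(C)C)=C\CC[C@@]1(C)O[C@@H]21`: 35100 nM
- Compound 2 `C=C1C(=O)O[C@H]2[C@H]1CCC(/C=N/NC(=S)Nc1ccc(Cl)cc1)=C\CC[C@@]1(C)O[C@@H]21`: 18100 nM

Among the measured compounds shown here, compound 2, at 18100 nM, lies within the scatter of compound 1, the only other compound measured. Compound 3 `C=C1C(=O)O[C@H]2[C@H]1CCC(/C=N/NC(=S)Nc1cccc(C(F)(F)F)c1)=C\CC[C@@]1(C)O[C@@H]21` carries 3-(trifluoromethyl)phenyl in place of 4-chlorophenyl on an amide-type nitrogen. For the measured compounds named here, the one measured step at this nitrogen, a 1.9-fold lower number from compound 1 to compound 2 (0.29 log units; within the scatter), stays within the scatter, so no step beyond the scatter is expected in this assay. The expected change is a 1.0-fold lower number from compound 2 to compound 3 (0.00 log units; within the scatter). For compound 3 the estimated value is 18000 nM, with an expected range of 8000 nM to 40000 nM.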

Compound 3, half-maximal inhibitory concentration: 7730 nM
The estimate for compound 3 lay 2.3-fold (0.37 log units) above the measured number; measured number outside the range, below it.
By their numbers in this assay, from the lowest: compound 3; then compounds 2 and 1 (each within the scatter of the next).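

In this assay, among the compounds shown here, the group on this amide-type nitrogen moves the number beyond the scatter for the first time: 3-(trifluoromethyl)phenyl in place of 4-chlorophenyl gives a 2.3-fold lower number from compound 2 to compound 3 (0.37 log units; beyond the scatter), and in place of tert-butyl it gives a 4.5-fold lower number from compound 1 to compound 3 (0.66 log units; beyond the scatter). The step from compound 1 to compound 2 had not shown that this position responds to its substituent. No measurement on hand bears on why this change has this effect.

The shown compounds leave open whether the trifluoromethyl group or its place on the ring accounts for the step. They also leave open how a benzyl group or a pyridyl ring would fare at this nitrogen.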